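Removing the Bromine From a Small Lactone

The compounds below may be only part of what the source reports. "The series", "measured", "known", "first", "only" and "open" are said of these compounds alone.

Going by the values given here, compound 2 `CC(=O)O[C@@H]1OC(=O)[C@](Br)(C(C)=O)[C@@H]1C` is the only compound here with a number: in a functional assay on DA-3 cells for cytotoxicity against DA-3 cell line (Mus musculus), read by MTT assay (a lower number here means a stronger inhibitor, a higher number a weaker inhibitor), compound 2 gives 6000 nM. Compound 1 `CC(=O)O[C@@H]1OC(=O)[C@](O)(C(C)=O)[C@@H]1C` shows only a limit, > 50000 nM, in this assay. The step of an at least 8.3-fold lower number from compound 1 to compound 2 (0.92 log units; beyond the scatter) rests on that limit (the limit of > 50000 nM in this assay, at which 1 of the 2 values shown sits). Compound 3 `CC(=O)O[C@@H]1OC(=O)[C@@H](C(C)=O)[C@@H]1C` differs from compound 2 by hydrogen in place of bromo on a saturated ring carbon. Among the compounds with values here, no measured step removes a bromo group, so the size of this step is uncertain. Compound 3 is expected to be a weaker inhibitor, a step of a 4.2-fold higher number from compound 2 to compound 3 (0.62 log units; beyond the scatter), with an estimated value of 25000 nM between 6000 nM and 60000 nM.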

Compound 3, half-maximal inhibitory concentration: > 50000 nM
Compound 3 gave a limit, no number; the forecaster's own chance of this, stated with the estimate: 40%; at least 2.0-fold (0.30 log units) between middle value and limit.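

Replacing the bromo group on this saturated ring carbon with hydrogen gives an at least 8.3-fold higher number from compound 2 to compound 3 (0.92 log units; beyond the scatter), so in this assay compound 2 owes its measurable number to the bromo group, at least among these compounds. Hydrogen, like hydroxy before it, fails to keep that number, which shows that the loss is not peculiar to hydroxy. The step from compound 1 to compound 3 cannot be read, because both values are limits: the limit of > 50000 nM in this assay, at which 2 of the 3 values shown sit.

On these data alone, whether chlorine, iodine or an amine on this ring carbon would come close to compound 2 stays open.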